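A few compounds are considered here, and "the series" means these few. Any claim that something is new, unique, unknown or untested is made for them only; others in the source may bear on it.

Among the measured compounds shown here, compound 2 `COc1ccc(C(=O)Nc2ccccc2Br)cc1OC1CCCC1` gives the lowest of the two numbers so far in an assay on isolated protein for inhibition of phosphodiesterase 4A (Sus scrofa) (on this read-out lower numbers stand for stronger inhibition and higher numbers for weaker inhibition), namely 130 nM; its only neighbour is compound 1 `COc1ccc(C(=O)Nc2ccccc2F)cc1OC1CCCC1`, which in this assay gives 10700 nM. For the measured compounds named here, the single measured step, an 82-fold lower number from compound 1 to compound 2 (1.92 log units; beyond the scatter), concerns the halogen on the same aromatic ring that compound 3 `COc1ccc(C(=O)Nc2cccc(Cl)c2Cl)cc1OC1CCCC1` alters: 2,3-dichlorophenyl in place of 2-bromophenyl on an amide-type nitrogen. Going by the values given here, with only that large step to go by, the estimate for compound 3 in this assay is 200 nM, expected to lie between 50 nM and 800 nM. This estimate means a step of a 1.5-fold higher number from compound 2 to compound 3 (0.19 log units; within the scatter), expected to be within or near the scatter.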

Compound 3, half-maximal inhibitory concentration: > 200000 nM
Compound 3 gave a limit, no number; the forecaster's own chance of this, stated with the estimate: 2%; at least 1000-fold (3.00 log units) between middle value and limit.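

Compound 3's reading is a limit of the assay, not a number: the limit of > 200000 nM in this assay, at which 1 of the 3 values shown sits.

With 2,3-dichlorophenyl on the amide-type nitrogen, the steps are an at least 1500-fold higher number from compound 2 to compound 3 (3.18 log units; beyond the scatter) and an at least 18-fold higher number from compound 1 to compound 3 (1.27 log units; beyond the scatter), so compound 3 is the weakest of the three in this assay. The earlier pair showed only that exchanging one halogen for another alters inhibition here; this change shows that a halogenated phenyl at this place can fall far behind even compound 1.

The compounds shown leave open whether the chlorine itself or the second halogen accounts for this, as two things change at once. From the compounds shown here alone, how 2-chlorophenyl or 3-chlorophenyl would read at this nitrogen remains open.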